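The compounds below may be only part of what the source reports. "The series", "measured", "known", "first", "only" and "open" are said of these compounds alone.

Compound 1 `Cc1nc2c(/C=C/c3ccccc3)cccn2c1C`: 7.2
Compound 2 `Cc1nc2c(CCc3ccccc3)cccn2c1N`: 7.3

Both compounds were measured in a physicochemical assay for acid dissociation. Compound 1 gives the lower of the two numbers, but compound 2 sits within the usual scatter of it, so the two cannot be told apart. Compound 3 `Cc1nc2c(/C=C\c3ccccc3)cccn2c1C` has not been measured; compared with compound 1, (the two compounds have the same atoms and bonds and differ only in configuration as drawn: 1 of 1 stereo elements differ; a double bond is drawn E in compound 1 and Z in compound 3). Among the measured compounds shown here, no step between measured compounds shows what such a change does. Since nothing leaves or enters, the step from compound 1 to compound 3 is expected to be none beyond the scatter no change at the digits printed from compound 1 to compound 3 (within the scatter). Compound 3 is therefore estimated at 7.2, ranging from 6.8 to 7.6.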

Compound 3, acid dissociation constant: 7.2
Compound 3: the middle estimate sits on the measured number at the digits printed; the measured number falls inside the stated range.
By their numbers in this assay, from the lowest: compounds 1, 3 and 2 (each within the scatter of the next).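

In this assay, changing the double bond from E to Z gives no change at the digits printed from compound 1 to compound 3 (within the scatter). Among the compounds shown here, this is the first comparison at this position that can be read directly, as compound 1 and compound 2 differ in more than one place. Only one thing varies in this pair: the fact that compounds 1 and 3 differ only in the configuration as drawn

The compounds shown leave open whether a longer chain in place of this double bond, or a carboxylic acid at this position, would move the number beyond the scatter.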